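This account rests on a few compounds, and the source may have more. Where it says the series, first, only, none or still open, it means among the compounds named here.

Measured compounds:
compound 1, `C#C[C@H](O)/C=C/CCCCCCCCC/C=C\CCCCCCCCC/C=C/[C@@H](O)C#C`, gives 160 nM
compound 2, `C#C[C@H](O)/C=C/CCCCCCCCC/C=C\CCCCCCCCCCC/C=C/[C@@H](O)C#C`, gives 160 nM
compound 3, `C#C[C@H](O)/C=C/CCCCCCC/C=C\CCCC/C=C\CCCCCCCCC/C=C/[C@@H](O)C#C`, gives 160 nM

All three were tested in a functional assay on P388 cells (Mus musculus) for cytotoxicity; a lower number here means a stronger inhibitor, a higher number a weaker inhibitor. Compound 1 and compound 2 differ by a group of 8 heavy atoms (7 carbon, 1 oxygen; no ring) in place of a group of 6 heavy atoms (5 carbon, 1 oxygen; no ring), on a saturated chain carbon, nine bonds along the chain from a double-bonded chain carbon, and this step, no change at the digits printed from compound 1 to compound 2 (within the scatter), left the read-out where it was. Compound 3 shares the same two terminal alkyne-bearing ends as compound 1, but how its core differs from that of compound 1 is not broken down here; in this assay compound 3 stands level with compound 1 and compound 2.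

Compound 4, `C#C[C@H](O)/C=C/CCCCCCCCC/C=C\CCCC/C=C\CCCCCCCCC/C=C/[C@@H](O)C#C`, has not yet been measured. It differs from compound 3 by a group of 8 heavy atoms (7 carbon, 1 oxygen; no ring) in place of a group of 6 heavy atoms (5 carbon, 1 oxygen; no ring), on a saturated chain carbon, seven bonds along the chain from a double-bonded chain carbon. Among the compounds with values here, this is the same kind of change as the one from compound 1 to compound 2, but not the same: there the group sat nine bonds along the chain from a double-bonded chain carbon, here it sits seven bonds along the chain from a double-bonded chain carbon.

Because no change at the digits printed from compound 1 to compound 2 (within the scatter) was within the scatter, the analogous step is expected to be small as well, no change at the digits printed from compound 3 to compound 4 (within the scatter). On that basis compound 4 is estimated to give 160 nM in this assay, with a range of 80 nM to 320 nM. This expectation rests on a single precedent step and on the level reading of compound 3 at 160 nM, so it carries the uncertainty of one comparison only.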

Compound 4, half-maximal inhibitory concentration: 160 nM
Compound 4: middle estimate and measured number agree at the digits printed; measured number inside the range.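

In this assay, putting the group of 8 heavy atoms in place of the group of 6 heavy atoms, on a saturated chain carbon, seven bonds along the chain from a double-bonded chain carbon, gave no change at the digits printed from compound 3 to compound 4 (within the scatter). Set beside the earlier step, the two results read as follows: the same change on two cores in this assay, no change at the digits printed (within the scatter) from compound 1 to compound 2 and no change at the digits printed (within the scatter) from compound 3 to compound 4, 1.0-fold (0.00 log units) apart, within the scatter of two such steps. This shows that, on these two cores, the change carried over with the same outcome, a read-out that stayed level, but it rests on two steps only and does not show that the change would be equally silent on any other core or at any other place on the chain.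

The compounds shown leave open whether a much shorter chain or a much longer chain would shift the read-out, and whether an amine or a carboxylic acid in place of the hydroxyl, or a nitrile in place of the terminal alkyne, would keep it level. They also leave open whether the opposite configuration at the hydroxyl-bearing carbons would change the picture, and whether the level reading holds anywhere beyond this assay.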